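The compounds below may be only part of what the source reports. "The series", "measured", "known", "first", "only" and "open" are said of these compounds alone.

Measured so far:
compound 1 `COC(=O)CC/C(C)=C/Cc1c(OC)c(C)c2c(c1OCC#CCN1CCN(c3ccc(C#N)cc3)CC1)C(=O)OC2`: > 50000 nM
compound 2 `COC(=O)CC/C(C)=C/Cc1c(OC)c(C)c2c(c1OCC#CCN1CCC(Cc3ccccc3)CC1)C(=O)OC2`: > 50000 nM
compound 3 `COC(=O)CC/C(C)=C/Cc1c(OC)c(C)c2c(c1OCC#CCN1CCN(C(c3ccccc3)c3ccc(Cl)cc3)CC1)C(=O)OC2`: > 50000 nM

Of the compounds shown here, three built on one shared core have been tested in a functional assay on FaDu cells (Homo sapiens) for inhibition, read by sulforhodamine B assay; on this read-out higher numbers stand for weaker inhibition and lower numbers for stronger inhibition. In this assay compound 1 gives > 50000 nM, which is a limit of the assay and not a number. Compound 2 gives > 50000 nM, again only a limit. Compound 3 gives > 50000 nM, also a limit. Among the measured compounds shown here, all three values therefore rest at the limit of > 50000 nM in this assay, at which 3 of the 3 values shown sit, and compound 1 stands level with the other two there; no step between any pair of them can be read, since none of the three has a measured number.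

Compound 4 `COC(=O)CC/C(C)=C/Cc1c(OC)c(C)c2c(c1OCC#CCN1CCN(c3ccccc3OC)CC1)C(=O)OC2` has not yet been tested in this assay. Set against compound 1, the change is 2-methoxyphenyl in place of 4-cyanophenyl on an amine nitrogen in a ring. For the measured compounds named here, no measured step exists in this set to suggest that such a swap of one aromatic group for another on the amine nitrogen in a ring would move the read-out, so the step from compound 1 to compound 4 is expected to be a step that the limit leaves unreadable from compound 1 to compound 4, that is, nothing beyond the usual scatter. Compound 4 is accordingly estimated at 60000 nM, within a range from 20000 nM to 200000 nM, and this assay is expected most likely to report only a limit for it once more.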

Compound 4, half-maximal inhibitory concentration: > 50000 nM
Compound 4 gave a limit, no number (the forecaster's own chance of this, stated with the estimate: 85%); the middle value lies beyond the limit too.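

Compound 4, like compound 1, returns only a limit and not a number, so no step from one to the other can be read in this assay: the limit of > 50000 nM in this assay, at which 4 of the 4 values shown sit.

The compounds shown leave open whether any group on the amine nitrogen in a ring would give a measured number in this assay, and how 2-methoxyphenyl and 4-cyanophenyl truly compare.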